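Ethyl on the sulfonamide nitrogen of compound 2

The source may report more compounds than this note shows. Statements on the series, on what has been measured and on what is new or still open speak of the compounds shown alone.

- compound 1 `COc1ccc(OC)c(C(=O)NCCN(C)Cc2ccccc2)c1` gives 3 mg/kg in a functional assay on the whole organism with Rattus norvegicus as the target; on this read-out lower numbers stand for an effect already at smaller amounts and higher numbers for an effect only at larger amounts of compound
- compound 2 `COc1ccc(S(N)(=O)=O)cc1C(=O)NCCN(C)Cc1ccccc1` gives > 30 mg/kg in this assay, a limit
- compound 3 `CCNS(=O)(=O)c1ccc(OC)c(C(=O)NCCN(C)Cc2ccccc2)c1` is not yet measured

The value of compound 2 is only a limit (> 30 mg/kg). Compound 3 carries ethyl in place of hydrogen on a sulfonamide nitrogen. Among the compounds with values here, no measured step changes that nitrogen. The nearest evidence is sulfamoyl in place of methoxy on an aromatic carbon (an at least 10-fold higher number from compound 1 to compound 2 (1.00 log units; beyond the scatter)), an at least modest step. In this assay a small move to a lower number is therefore expected, and another limit would not surprise. The expected step is an at least 1.5-fold lower number from compound 2 to compound 3 (0.17 log units; that floor lies within the scatter) (an estimate). For compound 3 the estimated value is 20 mg/kg (expected range 6 mg/kg to 60 mg/kg).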

Compound 3, dose for half-maximal effect: > 30 mg/kg
Compound 3 gave a limit, no number (the forecaster's own chance of this, stated with the estimate: 45%); middle value at least 1.5-fold (0.17 log units) from the limit.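

Ethyl on the sulfonamide nitrogen does not recover a readable value: in this assay, ethylsulfamoyl in place of methoxy on an aromatic carbon still gives an at least 10-fold higher number from compound 1 to compound 3 (1.00 log units; beyond the scatter). The effect of ethyl in place of hydrogen on that nitrogen cannot be read because compound 2 and compound 3 share one limit: the limit of > 30 mg/kg in this assay, at which 2 of the 3 values shown sit.

Open, as far as these compounds go, is whether a longer chain such as butyl, or a benzyl group, on the sulfonamide nitrogen would give a number in this assay. Also open, from the compounds shown here alone, is how methylsulfonyl in place of methoxy on that aromatic carbon would read there.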